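Swapping the carbamate side chain in a cytotoxicity series

The source may report more compounds than this note shows. Statements on the series, on what has been measured and on what is new or still open speak of the compounds shown alone.

Compound 3, `CCCCC1CCC(OC(=O)N[C@@H](CC(C)C)C(=O)N[C@@H](C[C@@H]2CCNC2=O)C(O)S(=O)(=O)O)CC1`, is one of three compounds tested in a toxicity assay on L929 cells (Mus musculus) for cytotoxicity; on this read-out lower numbers stand for higher toxicity in this test and higher numbers for lower toxicity in this test. Compound 1, `O=C[C@H](C[C@@H]1CCNC1=O)NC(=O)[C@H](CC1CCCCC1)NC(=O)c1cc2ccccc2[nH]1`, reaches only a limit of this assay, giving > 100000 nM. Compound 2, `CCCCC1CCC(OC(=O)N[C@@H](CC(C)C)C(=O)N[C@H](C=O)C[C@@H]2CCNC2=O)CC1`, gives 63300 nM, and compound 3 gives 59100 nM. Compound 3 thus has the lowest of the two numbers shown, but the gap to compound 2 is small: the change a 1.1-fold lower number from compound 2 to compound 3 (0.03 log units; within the scatter) lies within the scatter. Within the data shown here, that is the only measured step, and it concerns the chain carbon bound to the amide-type nitrogen, not the part of the molecule altered next.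

Compound 4, `CC(C)C[C@H](NC(=O)OCC1CCC(F)(F)CC1)C(=O)N[C@@H](C[C@@H]1CCNC1=O)C(O)S(=O)(=O)O`, differs from compound 3 by a group of 9 heavy atoms (7 carbon, 2 fluorine; one six-membered non-aromatic ring of carbon only) in place of a group of 10 heavy atoms (10 carbon; one six-membered non-aromatic ring of carbon only), on an oxygen next to a carbonyl group. Among the measured compounds shown here, no measured step touches this position, so the expectation can rest only on the observation that the one measured change did not move the number beyond the scatter. For compound 4 the expected step of a 1.0-fold higher number from compound 3 to compound 4 (0.01 log units; within the scatter) is therefore none beyond the scatter. Compound 4 is estimated at 60000 nM, with a range from 25000 nM to 150000 nM.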

Compound 4, half-maximal cytotoxic concentration: > 100000 nM
Compound 4 gave a limit, no number (the forecaster's own chance of this, stated with the estimate: 35%); middle value at least 1.6-fold (0.22 log units) away from the limit.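

Among these compounds, compound 4 carries (4,4-difluorocyclohexyl)methyl on an oxygen next to a carbonyl group, and this gives the first measured step at this position in this assay: an at least 1.6-fold higher number from compound 3 to compound 4 (0.22 log units; that floor lies within the scatter). Compound 4 gives > 100000 nM, which is a limit of the assay and not a number. The step is therefore only a floor, and its true size stays unknown because the read-out ends in a limit here: the limit of > 100000 nM in this assay, at which 2 of the 4 values shown sit.

The compounds shown cannot tell whether the two fluorine atoms or the rest of the new group account for this result, since both change together. A plain cyclohexylmethyl group without fluorine, or a longer open chain on the same oxygen, would be needed to separate these parts of the change.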